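Swapping the aryl group on a shared thiadiazole-free core

A few compounds are considered here, and "the series" means these few. Any claim that something is new, unique, unknown or untested is made for them only; others in the source may bear on it.

Measured so far:
Compound 1, `Cc1ccc(NC(=O)CSc2snnc2-c2ccc(F)cc2F)c(Br)c1`: > 273000 nM
Compound 2, `COc1ccc(-c2nnsc2SCC(=O)Nc2ccccc2[N+](=O)[O-])cc1`: >= 280000 nM

In an ADME assay on MT4 cells (Homo sapiens) for cytotoxicity (a higher number here means that more compound is tolerated, a lower number that less compound is tolerated), compound 2 gives >= 280000 nM, and this is a limit of the assay rather than a number. In this assay compound 1 gives > 273000 nM, likewise a limit. Compound 2 therefore stands at the top of what is shown, alongside compound 1, as the limit of >= 280000 nM in this assay, at which 1 of the 2 values shown sits, and the limit of > 273000 nM in this assay, at which 1 of the 2 values shown sits, record.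

Compound 3, `O=C(CSc1snnc1-c1ccc(F)cc1F)Nc1ccccc1[N+](=O)[O-]`, differs from compound 2 by 2,4-difluorophenyl in place of 4-methoxyphenyl on an aromatic carbon. Compound 1 already carries the 2,4-difluorophenyl and sits at its limit, so no step beyond the scatter is expected in either direction. The step of a number no higher from compound 2 to compound 3 (the limit leaves the size open) is estimated as none beyond the scatter. Compound 3 is expected to give about 280000 nM in this assay, within a range of 150000 nM to 450000 nM, and most likely again only as a limit.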

Compound 3, half-maximal cytotoxic concentration: 165000 nM
Compound 3: middle estimate off by 1.7-fold (0.23 log units), on the high side; the range from low to high includes it.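

Compound 3 is the first of the compounds shown to give a number rather than a limit of the assay, so this series can reach a measurable half-maximal cytotoxic concentration in this assay without any change to the shared core. Swapping 2,4-difluorophenyl for 4-methoxyphenyl gives an at least 1.6-fold lower number from compound 2 to compound 3 (0.22 log units; that floor lies within the scatter) at this aromatic carbon, and swapping 2-nitrophenyl for 2-bromo-4-methylphenyl gives an at least 1.6-fold lower number from compound 1 to compound 3 (0.21 log units; that floor lies within the scatter) on the amide-type nitrogen. Each step starts from a limit, so its full size stays open, and neither change is yet shown to go beyond the scatter.

The compounds shown leave open what a carboxylic acid or an amine on the aromatic ring at this place would give in this assay. Nothing shown bears on a cause for the number given by compound 3.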